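A Piperidinyl Substituent on a Core Without Readable Inhibition

The compounds below may be only part of what the source reports. "The series", "measured", "known", "first", "only" and "open" are said of these compounds alone.

Compound 1 `Nc1nc2ccccn2c1-c1ccc(O)cc1` in an assay on isolated protein for inhibition of ubiquitin carboxyl-terminal hydrolase 47 (Homo sapiens) (on this read-out higher numbers stand for weaker inhibition and lower numbers for stronger inhibition), gives > 100000 nM, which is a limit of the assay and not a number.
Compound 2 `Nc1nc2c(C(F)(F)F)cccn2c1-c1ccc(O)cc1` in this assay gives > 100000 nM, likewise a limit of the assay.

For the measured compounds named here, compound 1 thus stands only at a limit in this assay, and the one further value shown is a limit as well. Going by the values given here, the single measured step, a step that the two limits leave unreadable from compound 1 to compound 2, cannot be read in size or direction because both of its ends sit at the limit of > 100000 nM in this assay, at which 2 of the 2 values shown sit.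

Compound 3 `Nc1nc2cc(C3CCNCC3)ccn2c1-c1ccc(O)cc1` differs from compound 1 by piperidin-4-yl in place of hydrogen on an aromatic carbon. No measured step bears readably on this change, so the numbers shown give neither a size nor a direction for it. The expectation for compound 3 therefore rests on compound 1 alone, whose value > 100000 nM is only a limit. The step of a number no higher from compound 1 to compound 3 (the limit leaves the size open) is the one expected, meaning none readable beyond the scatter. Compound 3 is estimated at 100000 nM in this assay, with a range from 20000 nM to 500000 nM, and most likely the assay again reports only a limit.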

Compound 3, half-maximal inhibitory concentration: > 100000 nM
Compound 3 was reported as a limit (the forecaster's own chance of this, stated with the estimate: 75%); the middle value sits exactly at the limit.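

Compound 3, like compound 1, stands only at a limit in this assay, so no step between them can be read in size or direction: the limit of > 100000 nM in this assay, at which 3 of the 3 values shown sit.

The compounds shown leave open how strongly the shared core inhibits and whether piperidin-4-yl or trifluoromethyl changes that inhibition at all.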